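A few compounds are considered here, and "the series" means these few. Any claim that something is new, unique, unknown or untested is made for them only; others in the source may bear on it.

Among the compounds with values here, compound 1, with the structure `COc1ncnc2c1c(I)cn2[C@@H]1O[C@H](CO)[C@@H](O)[C@H]1O`, is the only compound here that gives a number in an ADME assay on MRC5 cells (Homo sapiens), read by MTT assay, with a stated time of 72 h; on this read-out higher numbers stand for weaker inhibition and lower numbers for stronger inhibition: compound 1 gives 63000 nM. Compound 2, with the structure `Nc1nc2c(c(-c3ccccc3)cn2[C@@H]2O[C@H](CO)[C@@H](O)[C@H]2O)c(=O)[nH]1`, reaches only a limit of the assay in this assay, where compound 2 gives > 100000 nM. That limit is the one noted as the limit of > 100000 nM in this assay, at which 1 of the 2 values shown sits. Within the data shown here, compound 1 therefore stands on the single number in this set, with the other measured compound sitting at the limit.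

Compound 3, with the structure `COc1ncnc2c1c(-c1ccccc1)cn2[C@@H]1O[C@H](CO)[C@@H](O)[C@H]1O`, has not yet been tested. Compared with compound 1 its change is phenyl in place of iodo on an aromatic carbon. Among the measured compounds shown here, no step between two measured compounds shows what this exchange does, so no size can be read from a measured pair. For the measured compounds named here, the values of compound 1 and compound 2 show only that a compound carrying a phenyl, on a different core, sat at the limit. The step from compound 1 to compound 3 is expected to be small, within the usual scatter or slightly towards weaker inhibition, estimated as a 1.3-fold higher number from compound 1 to compound 3 (0.10 log units; within the scatter). Compound 3 is therefore estimated at 80000 nM, with a range from 30000 nM to 200000 nM in this assay, and it may well return only a limit.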

Compound 3, half-maximal inhibitory concentration: > 100000 nM
Compound 3: no number, only a limit; the forecaster's own chance of this, stated with the estimate: 40%; middle value at least 1.2-fold (0.09 log units) from the limit.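

Within the data shown here, this is the first measured pair for this exchange: on this aromatic carbon, two ring bonds from the ring nitrogen, phenyl in place of iodo gives an at least 1.5-fold higher number from compound 1 to compound 3 (0.20 log units; that floor lies within the scatter) in this assay. The step is only a floor, so it does not establish a real change, and it shows no move towards stronger inhibition on the core of compound 1. Its true size cannot be read because compound 3 gives only a limit of the assay, > 100000 nM, and that limit is shared with compound 2: the limit of > 100000 nM in this assay, at which 2 of the 3 values shown sit.

The compounds shown leave open what an amine, a carboxylic acid or a longer carbon chain on this aromatic carbon would give in this assay, and whether any of these groups would return a number rather than a limit. They also leave open whether iodo and phenyl would differ in the same direction on the core of compound 2, where only the phenyl form appears here.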